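This account rests on a few compounds, and the source may have more. Where it says the series, first, only, none or still open, it means among the compounds named here.

In a functional assay on M21 cells (Homo sapiens) for inhibition, read by sulforhodamine B assay, with a stated time of 48 h (on this read-out higher numbers stand for weaker inhibition and lower numbers for stronger inhibition), compound 1 `CCNC(=O)Nc1ccc(/C=C/c2cccc(Cl)c2)cc1` gives > 20000 nM, and this is a limit of the assay, not a number. Compound 3 `O=C1NCCN1c1ccc(/C=C/c2cccc(Cl)c2)cc1` keeps the core of compound 1 with one change: 2-oxoimidazolidin-1-yl in place of (ethylcarbamoyl)amino on an aromatic carbon. Compound 2 `Cc1cc(C)cc(/C=C\c2ccc(N3CCNC3=O)cc2)c1` carries the same 2-oxoimidazolidin-1-yl and gives 10 nM, which points towards stronger inhibition, although compound 2 also differs from compound 3 elsewhere, so it is only a loose guide. The expected change is an at least 3.3-fold lower number from compound 1 to compound 3 (0.52 log units; beyond the scatter), a modest move towards stronger inhibition. Compound 3 is estimated at 6000 nM, with an expected range of 1000 nM to 20000 nM.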

Compound 3, half-maximal inhibitory concentration: 19000 nM
The estimate for compound 3 lay 3.2-fold (0.50 log units) below the measured number; measured number inside the range.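

In this assay, putting 2-oxoimidazolidin-1-yl in place of (ethylcarbamoyl)amino on this aromatic carbon gives an at least 1.0-fold lower number from compound 1 to compound 3 (0.02 log units; that floor lies within the scatter). Compound 3 gives 19000 nM, a real number, so on this core the new ring alone brings only weak inhibition. The value of compound 1 is a limit, not a number, so the true size of the step stays unknown: the limit of > 20000 nM in this assay, at which 1 of the 3 values shown sits.

The compounds shown leave open how a plain amine or a carboxylic acid would read at this place on the same core.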